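Chloro for isopropyl on the shared aryl ketone acid core

The source may hold more compounds than are shown below. What is called first, only, known or untested is meant among the compounds shown, and "the series" means these compounds.

In a functional assay on HeLa cells (Homo sapiens) for inhibition (on this read-out lower numbers stand for stronger inhibition and higher numbers for weaker inhibition), compound 2 `CC(C)c1ccc(C(=O)CC(SCC(=O)O)C(=O)O)cc1` gives 3330 nM, the highest of the three numbers in hand. Compound 1 `Cc1ccc(C)c(C(=O)CC(SCC(=O)O)C(=O)O)c1` gives 2680 nM and compound 3 `CCCCCCCCCCCCc1ccc(C(=O)CC(SCC(=O)O)C(=O)O)cc1` gives 1710 nM; both lie within the scatter of compound 2, so no order among the three can be read from this assay. Compound 4 `O=C(O)CSC(CC(=O)c1ccc(Cl)cc1)C(=O)O` has not yet been measured; it differs from compound 2 by chloro in place of isopropyl on an aromatic carbon. Going by the values given here, no step between measured compounds covers a change of this kind, and the three numbers in hand sit close together, so for compound 4 no step beyond the scatter is expected. The estimate for compound 4 in this assay is 3000 nM, with a range from 1200 nM to 7500 nM. The expected step is a 1.1-fold lower number from compound 2 to compound 4 (0.05 log units; within the scatter).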

Compound 4, half-maximal inhibitory concentration: 17200 nM
The estimate for compound 4 lay 5.7-fold (0.76 log units) below the measured number; measured number outside the range, above it.
By their numbers in this assay, from the lowest: compounds 3, 1 and 2 (each within the scatter of the next); then compound 4.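

In this assay, going by these compounds alone, chloro in place of isopropyl on an aromatic carbon, para to a large group, gives a 5.2-fold higher number from compound 2 to compound 4 (0.71 log units; beyond the scatter), the only step beyond the scatter. Within the data shown here, this position is therefore not indifferent to its substituent, which the close numbers of the earlier compounds could not show. Nothing in hand bears on the cause of this step. The compounds shown leave open whether the step follows from chloro itself or from the absence of an alkyl group at this position. Methyl, bromo or methoxy at the same position would help separate the two.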